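The compounds below may be only part of what the source reports. "The series", "measured", "known", "first", "only" and "open" are said of these compounds alone.

Three compounds built on a shared core have been examined in an ADME assay on microsomes from liver (Homo sapiens) for metabolic stability, read by LC-MS, using NADPH, with a stated time of 45 min, tested at 0.5 uM; on this read-out higher numbers stand for fast clearance and lower numbers for slow clearance. Compound 1 `CN1CCN(C(=O)CCSc2nc3cc(Cl)ccc3o2)CC1` gives 1.5 mL/min/g in this assay. Compound 2 `CN(C(=O)CCSc1nc2cc(Cl)ccc2o1)C1CCS(=O)(=O)C1` gives 1.5 mL/min/g, and compound 3 `O=C(CCSc1nc2cc(Cl)ccc2o1)N1CCS(=O)(=O)C1` gives 1.7 mL/min/g. Compound 3 sits at the upper edge of these three numbers, yet its gaps to compound 1 and to compound 2 both fall within the scatter, so the three cannot be told apart in this assay. Within the data shown here, the single measured step that changes the group on the carbonyl carbon, a 1.1-fold higher number from compound 1 to compound 3 (0.05 log units; within the scatter), shows that swapping one amide substituent for another left the read-out essentially unchanged.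

Compound 4 `CN(C)C(=O)CCSc1nc2cc(Cl)ccc2o1` has not yet been measured. Its structure differs from compound 3 in one place: dimethylamino in place of 1,1-dioxo-1,3-thiazolidin-3-yl on a carbonyl carbon. This is again a swap of the group on the carbonyl carbon, the same kind of change as from compound 1 to compound 3, which stayed within the scatter. On that basis the expected step of a 1.1-fold lower number from compound 3 to compound 4 (0.03 log units; within the scatter) is none beyond the scatter in either direction. Compound 4 is therefore estimated at 1.6 mL/min/g in this assay, with a likely range from 0.8 mL/min/g to 3.2 mL/min/g.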

Compound 4, intrinsic clearance in a liver preparation (reported as CLH), per the amount of preparation that the assay uses: 2.7 mL/min/g
For compound 4 the middle estimate is 1.7-fold (0.23 log units) below the measured one; measured number inside the range.
By their numbers in this assay, from the lowest: compounds 1, 2, 3 and 4 (each within the scatter of the next).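

Across this assay, the change on the carbonyl carbon now covers a much plainer group, since dimethylamino has no ring and 3 heavy atoms, whereas the 1,1-dioxo-1,3-thiazolidin-3-yl it replaces has a five-membered ring and 7 heavy atoms. Even so, the data show a 1.6-fold higher number from compound 3 to compound 4 (0.20 log units; within the scatter), along with a 1.8-fold higher number from compound 1 to compound 4 (0.26 log units; within the scatter) and, for methyl in place of 1,1-dioxothiolan-3-yl on the amide-type nitrogen, a 1.8-fold higher number from compound 2 to compound 4 (0.26 log units; within the scatter), so neither a ring in this group nor its 2 hydrogen-bond acceptors is needed for the number to stay within the scatter of the three earlier compounds. No measurement shown here accounts for these numbers.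

The compounds shown leave open whether a group on the carbonyl carbon of another kind, such as a carboxylic acid, a primary amine or a longer chain like diethylamino, would give a step beyond the scatter. All four compounds also share the rest of the structure unchanged, so these numbers say nothing about how the read-out responds to a change in the saturated chain or in the shared core.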